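Forecast for a fluoro-methoxy cinnamamide from three measured analogues

The source may report more compounds than this note shows. Statements on the series, on what has been measured and on what is new or still open speak of the compounds shown alone.

Measured so far:
- compound 1, `COc1ccc(C(=O)c2cc(OC)c(OC)c(OC)c2)cc1NC(=O)/C=C/c1cc(OC)c(OC)c(OC)c1`: 1200 nM
- compound 2, `COc1ccc(/C=C/C(=O)Nc2cc(C(=O)c3cc(OC)c(OC)c(OC)c3)ccc2OC)cc1`: 8700 nM
- compound 3, `COc1ccc(C(=O)c2cc(OC)c(OC)c(OC)c2)cc1NC(=O)/C=C/c1ccc(C(F)(F)F)cc1`: 100 nM

All three share a core and differ only in the aryl group at the far end of the chain. In a functional assay on B16 cells (Mus musculus) for cytotoxicity, read by MTT assay, with a stated time of 72 h (on this read-out lower numbers stand for stronger inhibition and higher numbers for weaker inhibition), compound 3 gives the lowest number of the three; its nearest neighbour is compound 1, at a 12-fold lower number from compound 1 to compound 3 (1.08 log units; beyond the scatter) read in reverse, and compound 2 lies furthest away, an 87-fold lower number from compound 2 to compound 3 (1.94 log units; beyond the scatter) read in reverse.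

Compound 4, `COc1cc(/C=C/C(=O)Nc2cc(C(=O)c3cc(OC)c(OC)c(OC)c3)ccc2OC)ccc1F`, has not yet been measured. It differs from compound 3 in one place: 4-fluoro-3-methoxyphenyl in place of 4-(trifluoromethyl)phenyl on a double-bonded chain carbon bound to a double-bonded chain carbon. Among the measured compounds shown here, two measured steps bear on this change. Swapping trimethoxyphenyl for methoxyphenyl gave a 7.3-fold higher number from compound 1 to compound 2 (0.86 log units; beyond the scatter), and swapping methoxy for trifluoromethyl on the aromatic carbon gave an 87-fold lower number from compound 2 to compound 3 (1.94 log units; beyond the scatter). Both say that moving away from the trifluoromethyl-bearing ring toward a methoxy-bearing ring raises the number in this assay, and compound 4 keeps one methoxy and gives up the trifluoromethyl. A rise beyond the scatter is therefore expected, estimated at a 15-fold higher number from compound 3 to compound 4 (1.18 log units; beyond the scatter). Compound 4 is expected to give about 1500 nM, within a range of 300 nM to 7000 nM.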

Compound 4, half-maximal inhibitory concentration: 16300 nM
Estimate against measurement, compound 4: 11-fold (1.04 log units) below; the measured number lies above the stated range.
By their numbers in this assay, from the lowest: compound 3; then compound 1; then compounds 2 and 4 (each within the scatter of the next).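

In this assay, the move to 4-fluoro-3-methoxyphenyl gives a 160-fold higher number from compound 3 to compound 4 (2.21 log units; beyond the scatter) and is the largest step among these compounds, so the low number of compound 3 does not carry over to every ring that holds fluorine. Set against the 4-methoxyphenyl ring, the same ring gives a 1.9-fold higher number from compound 2 to compound 4 (0.27 log units; within the scatter) and so cannot be told apart from it, which means that adding a single fluorine to a methoxy-bearing ring brought no readable gain in this pair. Set against 3,4,5-trimethoxyphenyl, it gives a 14-fold higher number from compound 1 to compound 4 (1.13 log units; beyond the scatter) and shows that a ring with one methoxy group and one fluorine does not recover the level reached with three methoxy groups, so neither fluorine nor methoxy alone sorts the rings at this position.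

Still open, from the compounds shown here alone, is whether a nitrile or a carboxylic acid in place of the trifluoromethyl group would keep the number near that of compound 3 or not. Nothing measured here explains why these rings differ so widely.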